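The source may report more compounds than this note shows. Statements on the series, on what has been measured and on what is new or still open speak of the compounds shown alone.

Measured compounds in this series:
compound 1 `COc1cc(C)cc(-c2c(-c3ccnc(-c4ccc(C(C)=O)cc4)c3)cnn2CC#N)c1`, 1930 nM
compound 2 `COc1cc(C)cc(-c2nn(CC#N)cc2-c2ccc(-c3cccc(C(C)=O)c3)nc2)c1`, 1640 nM
compound 3 `Cc1cc(O)cc(-c2nn(CC#N)cc2-c2ccnc(-c3ccc(Oc4ccccc4)cc3)c2)c1`, 2720 nM

All three values come from a functional assay on NCI-H522 cells (Homo sapiens) for inhibition, read by sulforhodamine B assay, with a stated time of 48 h; on this read-out higher numbers stand for weaker inhibition of growth and lower numbers for stronger inhibition of growth. For the measured compounds named here, on these numbers compound 1 stands with compound 2 and compound 3 inside the usual scatter; compound 1 is not set apart from either of them, and no compound of the three can be called stronger or weaker than another.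

Compound 4 `COc1cc(C)cc(-c2c(-c3ccnc(-c4ccc(N(C)C)cc4)c3)cnn2CC#N)c1` is not yet measured. It differs from compound 1 in one place: dimethylamino in place of acetyl on an aromatic carbon. Going by the values given here, no measured pair shows this change, so there is no measured step to lean on. Without one, the step from compound 1 to compound 4 in this assay is expected to be a 1.0-fold higher number from compound 1 to compound 4 (0.02 log units; within the scatter), nothing beyond the scatter in either direction. Compound 4 is therefore estimated at 2000 nM, with a range from 700 nM to 6000 nM.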

Compound 4, concentration for 50% growth inhibition: 27 nM
Compound 4: middle estimate off by 74-fold (1.87 log units), on the high side; measured number outside the range, below it.
By their numbers in this assay, from the lowest: compound 4; then compounds 2, 1 and 3 (each within the scatter of the next).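

In this assay, the substituent on the aromatic carbon para to a large group turns out to be a sensitive place: dimethylamino in place of acetyl, with the heavy-atom count unchanged, gives a 71-fold lower number from compound 1 to compound 4 (1.85 log units; beyond the scatter) on a single change. The earlier compounds shown here sat within the scatter of one another and offered no one-place pair, so they gave no sign of this. Nothing on hand accounts for the step.

Open, going by these compounds, is whether dimethylamino itself is needed, or whether a primary amine, methoxy or pyrrolidine at this place would serve as well. Also open, on these data alone, is whether the same change carries over to the core of compound 2.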